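A Nitro Group Enters the Core of Compound 1

The compounds below may be only part of what the source reports. "The series", "measured", "known", "first", "only" and "open" are said of these compounds alone.

compound 1, `O=C(N/N=C/c1ccncc1)c1cc2ccccc2oc1=O`: 9750 nM
compound 2, `O=C(N/N=C/c1cccnc1)c1cc2ccccc2oc1=O`: 15300 nM

In a functional assay on PANC-1 cells (Homo sapiens) for antiproliferative activity, read by fluorescence and resazurin assay, with a stated time of 48 h (a lower number here means a stronger inhibitor, a higher number a weaker inhibitor), compound 1 gives 9750 nM and compound 2 gives 15300 nM. Compound 1 holds the lower of the two numbers, but the step to compound 2, a 1.6-fold higher number from compound 1 to compound 2 (0.20 log units; within the scatter), leaves the two indistinguishable. Compound 3, `O=C(N/N=C/c1ccncc1)c1cc2cc([N+](=O)[O-])ccc2oc1=O`, awaits measurement. It differs from compound 1 by nitro in place of hydrogen on an aromatic carbon. Going by the values given here, no measured step touches this part of the shared core; the only step, a 1.6-fold higher number from compound 1 to compound 2 (0.20 log units; within the scatter), changes the carbon with a double bond to nitrogen and stays within the scatter. The expectation for compound 3 is therefore no step beyond the scatter, a 1.1-fold lower number from compound 1 to compound 3 (0.03 log units; within the scatter). Compound 3 is estimated at 9000 nM, within 3000 nM to 30000 nM.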

Compound 3, half-maximal inhibitory concentration: 26100 nM
The estimate for compound 3 lay 2.9-fold (0.46 log units) below the measured number, within the range that was stated.
By their numbers in this assay, from the lowest: compounds 1, 2 and 3 (each within the scatter of the next, the first and the last beyond it).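

Nitro in place of hydrogen on an aromatic carbon of the shared core gives a 2.7-fold higher number from compound 1 to compound 3 (0.43 log units; beyond the scatter) in this assay, so this position is not indifferent to substitution. The step is modest, yet it clears the scatter, which the change at the carbon with a double bond to nitrogen, a 1.6-fold higher number from compound 1 to compound 2 (0.20 log units; within the scatter), did not.

As far as these compounds go, whether an amine or a carboxylic acid at this aromatic carbon would move the number the same way remains open, as does whether nitro would have the same effect alongside the pyridin-3-yl of compound 2. Nothing available explains the step.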